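A Smaller Ring on the Amine Side of Compound 2

A few compounds are considered here, and "the series" means these few. Any claim that something is new, unique, unknown or untested is made for them only; others in the source may bear on it.

Of the compounds shown here, three have so far been measured in an assay for inhibition of Caspase-8 (Homo sapiens); a higher number here means a weaker inhibitor, a lower number a stronger inhibitor. Compound 1 `CCC(C(=O)N[C@@H](CC(=O)O)C(=O)CNCN1CCCCC1)n1cc(C(C)(C)C)nc(NCc2nonc2C)c1=O` gives > 10000 nM, which is a limit of the assay rather than a number. Compound 2 `CCC(C(=O)N[C@@H](CC(=O)O)C(=O)CNCN1CCc2ccccc2C1)n1ccnc(NCc2nonc2C)c1=O` gives 7380 nM, and compound 3 `CCC(C(=O)N[C@@H](CC(=O)O)C(=O)CSCc1ccccc1)n1ccnc(NCc2nc(C)no2)c1=O` gives 6420 nM. Of the two numbers, compound 2 stands as the higher, but its distance from compound 3 is within the usual scatter of repeated measurements, so the two cannot be told apart. No pair of these compounds differs in a single place, so no measured step is at hand.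

Compound 4 `CCC(C(=O)N[C@@H](CC(=O)O)C(=O)CNCN1CCCC1)n1ccnc(NCc2nonc2C)c1=O` has not yet been measured. It differs from compound 2 in one place: pyrrolidin-1-yl in place of 1,2,3,4-tetrahydroisoquinolin-2-yl on a saturated chain carbon bound to an amine nitrogen The measured compounds do not show the effect of this exchange on its own, and compound 1, which carries a different saturated ring at that place together with other changes, sits at a limit. A step of modest size toward a weaker inhibitor, or none beyond the scatter, is what is expected for the step of a 1.2-fold higher number from compound 2 to compound 4 (0.09 log units; within the scatter). Compound 4 is therefore expected to give about 9000 nM in this assay, with a range from 3000 nM to 30000 nM.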

Compound 4, half-maximal inhibitory concentration: 6220 nM
Compound 4: the middle estimate sits 1.4-fold (0.16 log units) above what was measured; measured number inside the range.
By their numbers in this assay, from the lowest: compounds 4, 3 and 2 (each within the scatter of the next). At a limit, above all of these: compound 1.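

For the compounds shown here, this is the first measured step at this place, on a saturated chain carbon bound to an amine nitrogen, and it is a 1.2-fold lower number from compound 2 to compound 4 (0.07 log units; within the scatter). The group shrinks from 10 heavy atoms to 5 and loses its six-membered aromatic ring of carbon only, yet in this assay compound 2 and compound 4 cannot be told apart, so that aromatic ring is not needed to keep the number at this level. Compound 1 gives a limit and not a number, so it adds no measured size to this comparison: the limit of > 10000 nM in this assay, at which 1 of the 4 values shown sits.

Still open, from the compounds shown here alone, is whether a morpholine ring, which carries an oxygen in the ring, or an open-chain dimethylamino group at this place would move the number beyond the scatter. Going by these compounds, it is also open whether the exchange from 1,2,3,4-tetrahydroisoquinolin-2-yl to pyrrolidin-1-yl would read the same on the core of compound 1, which carries a tert-butyl group.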